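Methyl substitution in a ketone-linked bicyclic aminothiazole series

The source may hold more compounds than are shown below. What is called first, only, known or untested is meant among the compounds shown, and "the series" means these compounds.

Measured so far:
compound 1, `CN(C)c1nc(N)sc1C(=O)c1cnc2ccccn12`, 32%
compound 2, `Cc1ccn2c(C(=O)c3sc(N)nc3N(C)C)cnc2c1`, 85%
compound 3, `Cc1nc(N)sc1C(=O)c1cnc2ccccn12`, 53%

In a functional assay on the whole organism (strain Sprague-Dawley) for inhibition, with Rattus norvegicus as the target, read by paw edema, with stated times of 1 h and 3 h, at a dose of 50 mg/kg by the oral route (a lower number here means less inhibition, a higher number more inhibition at the dose given (going by the name of the read-out)), compound 1 gives 32%. Compound 2 differs from compound 1 by methyl in place of hydrogen on an aromatic carbon, and in this assay compound 2 gives 85%, a step of a number 53 percentage points higher from compound 1 to compound 2 (beyond the scatter). Compound 3 differs from compound 1 by methyl in place of dimethylamino on an aromatic carbon, and in this assay compound 3 gives 53%, a step of a number 21 percentage points higher from compound 1 to compound 3 (beyond the scatter).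

Compound 4, `Cc1nc(N)sc1C(=O)c1cnc2c(C)cccn12`, is not yet measured. It differs from compound 3 by methyl in place of hydrogen on an aromatic carbon. Within the data shown here, this is the same kind of change as the one from compound 1 to compound 2, but not the same: in compound 2 the methyl sits meta to a fused ring, opposite the ring nitrogen and para to a fused ring, whereas in compound 4 it sits ortho to a fused ring, two atoms from the ring nitrogen and meta to a fused ring. The two cores also differ, by methyl in place of dimethylamino on an aromatic carbon.

Among the measured compounds shown here, only one instance of this kind of change is measured, and it sits on a different place and a different core. The measured step of a number 53 percentage points higher from compound 1 to compound 2 (beyond the scatter) is therefore taken as an upper bound rather than as the expected size. The expected step from compound 3 to compound 4 in this assay is estimated at a number 17 percentage points higher from compound 3 to compound 4 (beyond the scatter), smaller than that upper bound. Compound 4 is expected to give about 70% in this assay, estimated between 45% and 90%.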

Compound 4, a percentage reported as inhibition, in the whole organism at one dose (the size of the read-out at that dose, not a potency): 45%
Compound 4: the middle estimate sits 25 percentage points above what was measured; low and high end bracket the measured number.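

In this assay methyl in place of hydrogen, ortho to a fused ring and two atoms from the ring nitrogen, gives a number 8 percentage points lower from compound 3 to compound 4 (within the scatter), so on this core and at this place the change has no effect that can be told from the scatter. The gain seen on the core of compound 1 therefore does not carry over as a fixed increment to every methyl in place of hydrogen in this series: the same change on two cores in this assay, a number 53 percentage points higher (beyond the scatter) from compound 1 to compound 2 and a number 8 percentage points lower (within the scatter) from compound 3 to compound 4, 61 percentage points apart, beyond the scatter of two such steps

This does not show that the core is what sets the outcome, since the methyl of compound 2 and the methyl of compound 4 also sit at different places, so core and place change together and the two steps cannot separate them.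

The compounds shown leave open how a methyl at the place it occupies in compound 2 behaves on the core of compound 3, and how a methyl at the place it occupies in compound 4 behaves on the core of compound 1, the two pairs that would tell place from core. They also leave open what an ethyl group, a methoxy group or a chlorine atom would do at either place on the fused ring.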